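The source may hold more compounds than are shown below. What is called first, only, known or untested is meant among the compounds shown, and "the series" means these compounds.

Notes on the series. Compound 1 `CC(C)Nc1nc(N)nc2c1ncn2/C=C1/CC1(CO)CO`, compound 2 `Nc1nc(NC2CC2)c2ncn(/C=C3/CC3(CO)CO)c2n1` and compound 3 `CCCNc1nc(N)nc2c1ncn2/C=C1/CC1(CO)CO` share one core and differ only in the group on a nitrogen on an aromatic ring. In an ADME assay on CCRF-HSB-2 cells (Homo sapiens) for cytotoxicity, with a stated time of 7 days (a higher number here means that more compound is tolerated, a lower number that less compound is tolerated), compound 1 gives > 20000 nM, which is a limit of the assay and not a number. In this assay compound 2 gives > 20000 nM, again a limit. In this assay compound 3 gives > 20000 nM, also a limit. Compound 3 thus stands where both other measured compounds stand. The three pairs give a step that the two limits leave unreadable from compound 1 to compound 2, a step that the two limits leave unreadable from compound 1 to compound 3 and a step that the two limits leave unreadable from compound 2 to compound 3, none with a readable size, because of the limit of > 20000 nM in this assay, at which 3 of the 3 values shown sit.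

Compound 4 `CCCOc1nc(N)nc2c1ncn2/C=C1/CC1(CO)CO` is not yet measured. Relative to compound 3 the change is propoxy in place of propylamino on an aromatic carbon. Among the measured compounds shown here, no measured step covers an exchange of propylamino for propoxy; the measured steps concern the group on the nitrogen only and all sit at the limit, so they give no direction. The expectation for compound 4 in this assay is therefore no step beyond the scatter, a step that the limit leaves unreadable from compound 3 to compound 4, with a further limit the likeliest report. Compound 4 is estimated at 40000 nM, in the range 15000 nM to 150000 nM.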

Compound 4, half-maximal cytotoxic concentration: > 20000 nM
Compound 4 gave a limit, no number; the forecaster's own chance of this, stated with the estimate: 85%; the middle value does not contradict the limit.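

No step between compound 4 and compound 1, compound 2 or compound 3 can be read in this assay, and the reason is a shared one: the limit of > 20000 nM in this assay, at which 4 of the 4 values shown sit. The compounds shown leave open whether propoxy and the three amino groups differ at all in this assay, as none has a value that is a number.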